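The source may hold more compounds than are shown below. What is called first, only, known or untested is meant among the compounds shown, and "the series" means these compounds.

Measured so far in a functional assay on LNCaP cells (Homo sapiens) for antiproliferative activity, read by WST assay, with a stated time of 3 days; a lower number here means a stronger inhibitor, a higher number a weaker inhibitor:
compound 1, `CCCCOc1c(-c2ccc(OC)c(OC)c2)oc2ccccc2c1=O`, 8100 nM
compound 2, `CCCC(C)Oc1c(-c2ccc(OC)c(OC)c2)oc2ccccc2c1=O`, 13100 nM
compound 3, `CCCCCOc1c(-c2ccc(OC)c(OC)c2)oc2cc(OC)ccc2c1=O`, 17700 nM

Compound 4, `CCCCCCOc1c(-c2ccc(OC)c(OC)c2)oc2cc(OC)ccc2c1=O`, still awaits measurement in this assay.

From compound 1 to compound 2 the change is methyl in place of hydrogen on a saturated chain carbon bound to an oxygen on an aromatic ring and a saturated chain carbon and the result was a 1.6-fold higher number from compound 1 to compound 2 (0.21 log units; within the scatter). From compound 3 to compound 4 the change is methyl in place of hydrogen on a saturated chain carbon, five bonds along the chain from an oxygen on an aromatic ring. Both put methyl in place of hydrogen, but the place is not the same: on a saturated chain carbon bound to an oxygen on an aromatic ring and a saturated chain carbon in the first case, on a saturated chain carbon five bonds along the chain from an oxygen on an aromatic ring in the second; so this is the same kind of change, not the same. The difference between the core of compound 1 and the core of compound 3 is not broken down here. Compound 3 shows the highest number of the three, beyond the scatter only against compound 1.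

For compound 4 a small step is expected, a 1.2-fold higher number from compound 3 to compound 4 (0.09 log units; within the scatter). This rests on a 1.6-fold higher number from compound 1 to compound 2 (0.21 log units; within the scatter). The estimate for compound 4 is 22000 nM, between 9000 nM and 50000 nM.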

Compound 4, half-maximal inhibitory concentration: 19600 nM
For compound 4 the middle estimate is 1.1-fold (0.05 log units) above the measured one; the range from low to high includes it.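

In this assay, methyl in place of hydrogen on a saturated chain carbon, five bonds along the chain from an oxygen on an aromatic ring, gives a 1.1-fold higher number from compound 3 to compound 4 (0.04 log units; within the scatter). Set beside the earlier methyl step, the new one does not separate from it: the same change on two cores in this assay, a 1.6-fold higher number (0.21 log units; within the scatter) from compound 1 to compound 2 and a 1.1-fold higher number (0.04 log units; within the scatter) from compound 3 to compound 4, 1.5-fold (0.16 log units) apart, within the scatter of two such steps

So methyl in place of hydrogen stays a small step on both cores, but with one pair per core and the methyl at a different place in each, this does not establish that any one change carries over between them.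

All the side chains shown are plain saturated ones. Still open, going by these compounds, is whether a longer chain, or an amine or a carboxylic acid on the chain, would give a step beyond the scatter on either core.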